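Swapping an Ethylphenyl for a Halogenated Phenyl

The source may hold more compounds than are shown below. What is called first, only, known or untested is meant among the compounds shown, and "the series" means these compounds.

Measured so far:
Compound 1, `C=CC(=O)Nc1cccc(NC(=O)CSc2nc(Nc3ccccc3)c3ccccc3n2)c1`: 8740 nM
Compound 2, `C=CC(=O)Nc1cccc(NC(=O)CSc2nc(Nc3ccccc3C)c3ccccc3n2)c1`: 23200 nM
Compound 3, `C=CC(=O)Nc1cccc(NC(=O)CSc2nc(Nc3ccc(CC)cc3)c3ccccc3n2)c1`: 24300 nM

The three compounds share one core and differ only in the ring carried on a nitrogen of that core. In a functional assay on PC-3 cells (Homo sapiens) for inhibition, read by MTT assay, with a stated time of 72 h (on this read-out higher numbers stand for weaker inhibition and lower numbers for stronger inhibition), compound 3 gives 24300 nM, the highest of the three numbers. It lies within the scatter of compound 2, which gives 23200 nM. It lies beyond the scatter of compound 1, which gives 8740 nM.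

Compound 4, `C=CC(=O)Nc1cccc(NC(=O)CSc2nc(Nc3ccc(F)c(Cl)c3)c3ccccc3n2)c1`, has not yet been measured. It differs from compound 3 in one place: 3-chloro-4-fluorophenyl in place of 4-ethylphenyl on a nitrogen on an aromatic ring. Among the compounds with values here, two measured steps bear on changes to this ring: a 2.7-fold higher number from compound 1 to compound 2 (0.42 log units; beyond the scatter) and a 2.8-fold higher number from compound 1 to compound 3 (0.44 log units; beyond the scatter), both raising the number when an alkyl group is added to the plain phenyl, while a 1.0-fold higher number from compound 2 to compound 3 (0.02 log units; within the scatter) shows that moving from one alkylphenyl to another changed nothing beyond the scatter. Within the data shown here, no measured compound carries a halogen on this ring, so the direction is uncertain; a halogenated ring is expected to fall somewhere between the plain phenyl and the alkylphenyls. Compound 4 is therefore estimated at 15000 nM (range 5000 nM to 45000 nM). This estimate means an expected step of a 1.6-fold lower number from compound 3 to compound 4 (0.21 log units; within the scatter).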

Compound 4, half-maximal inhibitory concentration: > 50000 nM
Compound 4: only a limit was reported; the forecaster's own chance of this, stated with the estimate: 5%; middle value at least 3.3-fold (0.52 log units) away from the limit.
By their numbers in this assay, from the lowest: compound 1; then compounds 2 and 3 (each within the scatter of the next). At a limit, above all of these: compound 4.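

Compound 4 is reported only as a limit, not as a number: the limit of > 50000 nM in this assay, at which 1 of the 4 values shown sits.

Even so, its steps in this assay can be read as minimum sizes: an at least 2.0-fold higher number from compound 3 to compound 4 (0.31 log units; beyond the scatter), an at least 2.1-fold higher number from compound 2 to compound 4 (0.33 log units; beyond the scatter) and an at least 5.7-fold higher number from compound 1 to compound 4 (0.75 log units; beyond the scatter). The earlier compounds shown here showed the number rising only when an alkyl group was added to the ring on the nitrogen, whereas the 3-chloro-4-fluorophenyl ring carries two halogens and no alkyl group, yet its number is higher still. Among these four compounds, every substituted ring therefore gives a higher number than the plain phenyl of compound 1, and none goes against this.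

As far as these compounds go, how far compound 4 truly lies past its limit stays open. Also open, from the compounds shown here alone, is how a ring carrying only chlorine, only fluorine, a methoxy group or an amine would read.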